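Carbamoylpyridinyl in Place of Carboxyphenyl on a Shared Core

A few compounds are considered here, and "the series" means these few. Any claim that something is new, unique, unknown or untested is made for them only; others in the source may bear on it.

compound 1, `NS(=O)(=O)c1ccccc1-c1cnc(C(=O)CCCCCCc2ccccc2)o1`: 1500 nM
compound 2, `COC(=O)c1cccc(-c2cnc(C(=O)CCCCCCc3ccccc3)o2)c1`: 12 nM
compound 3, `O=C(O)c1ccc(-c2cnc(C(=O)CCCCCCc3ccccc3)o2)cc1`: 60 nM

Three compounds share one core and differ only in the aromatic group attached to it. In an assay (Rattus norvegicus) for inhibition of Fatty-acid amide hydrolase 1 (Homo sapiens) (on this read-out lower numbers stand for stronger inhibition and higher numbers for weaker inhibition), compound 2 gives the lowest number, compound 3 stands second highest of the three, and compound 1 gives the highest number; both gaps from compound 3, to compound 2 and to compound 1, lie beyond the scatter of repeated measurements.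

Compound 4, `NC(=O)c1cccc(-c2cnc(C(=O)CCCCCCc3ccccc3)o2)n1`, has not yet been measured. It differs from compound 3 in one place: 6-carbamoylpyridin-2-yl in place of 4-carboxyphenyl on an aromatic carbon.

For the measured compounds named here, no measured pair in this set differs in exactly one place, so no measured step is at hand to calibrate the change. Judged from the spread of the three numbers, the group on the aromatic ring moves the read-out widely. Compound 4 is expected to give 10 nM, within a range from 2 nM to 50 nM. The step of a 6.0-fold lower number from compound 3 to compound 4 (0.78 log units; beyond the scatter) is expected to be a moderate downward one, beyond the scatter, because compound 2 gives 12 nM and shows that a lower number than that of compound 3 is reachable on this core.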

Compound 4, inhibition constant: 1 nM
For compound 4 the middle estimate is 10-fold (1.00 log units) above the measured one; the whole stated range lies above it.
By their numbers in this assay, from the lowest: compound 4; then compound 2; then compound 3; then compound 1.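

In this assay, for the compounds shown here, putting 6-carbamoylpyridin-2-yl in place of 4-carboxyphenyl gives a 60-fold lower number from compound 3 to compound 4 (1.78 log units; beyond the scatter), the only step in this set that changes a single place, and it is large and beyond the scatter. It shows that the read-out at this aromatic carbon, next to the ring oxygen, can move widely even when the leaving and entering groups have the same number of heavy atoms, each carry one six-membered aromatic ring and one hydrogen-bond donor, and have no net charge. No measurement offered here accounts for the size of this step.

As far as these compounds go, the exchange alters several things at once, since a ring carbon gives way to a ring nitrogen, the carboxylic acid gives way to a carbamoyl group and the substituent stands elsewhere on the ring, so the share of each in the step remains unknown. A carboxypyridinyl group and a carbamoylphenyl group on the same core would be the comparisons that could begin to separate the contribution of the ring nitrogen from that of the carbamoyl group.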